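Fluorine count on the cinnamamide ring: from one to three

The compounds below may be only part of what the source reports. "The series", "measured", "known", "first", "only" and "open" are said of these compounds alone.

Measured compounds so far:
compound 1 `COc1ccc(/C=C/C(=O)Nc2cc(C(=O)c3cc(OC)c(OC)c(OC)c3)cc(OC)c2OC)cc1OC` — 7800 nM
compound 2 `COc1cc(C(=O)c2cc(OC)c(OC)c(OC)c2)cc(NC(=O)/C=C/c2ccc(F)cc2)c1OC` — 6700 nM

Both compounds share a core carrying a trimethoxybenzoyl group and an amide-linked ethenyl chain ending in an aromatic ring. In a functional assay on DU-145 cells (Homo sapiens) for cytotoxicity, read by MTT assay, with a stated time of 72 h (on this read-out higher numbers stand for weaker inhibition and lower numbers for stronger inhibition), compound 1 gives 7800 nM and compound 2 gives 6700 nM. Going by the values given here, the only measured step, a 1.2-fold lower number from compound 1 to compound 2 (0.07 log units; within the scatter), changes the ring on the chain from 3,4-dimethoxyphenyl to 4-fluorophenyl. Compound 2 therefore stands at the lower of the two numbers, but it cannot be called the stronger of the pair.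

Compound 3 `COc1cc(C(=O)c2cc(OC)c(OC)c(OC)c2)cc(NC(=O)/C=C/c2cc(F)c(F)c(F)c2)c1OC` follows the same line of change: 3,4,5-trifluorophenyl in place of 4-fluorophenyl on a double-bonded chain carbon bound to a double-bonded chain carbon. Among the compounds with values here, no measured step adds fluorine to a ring that already carries one, so the only guide is the step from compound 1 to compound 2, which stayed inside the scatter when the whole ring was exchanged. A step of a similar, unremarkable size is expected in this assay for compound 3, with no clear direction, giving a 1.1-fold lower number from compound 2 to compound 3 (0.05 log units; within the scatter). The estimate for compound 3 is 6000 nM, with a range from 2500 nM to 15000 nM.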

Compound 3, half-maximal inhibitory concentration: 7900 nM
Compound 3: middle estimate off by 1.3-fold (0.12 log units), on the low side; low and high end bracket the measured number.
By their numbers in this assay, from the lowest: compounds 2, 1 and 3 (each within the scatter of the next).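

In this assay, going by these compounds alone, putting 3,4,5-trifluorophenyl in place of 4-fluorophenyl on the double-bonded chain carbon gives a 1.2-fold higher number from compound 2 to compound 3 (0.07 log units; within the scatter) and so offers the first direct look at the fluorine count on this ring: going from one fluorine to three leaves no readable difference between the two numbers. Putting 3,4,5-trifluorophenyl in place of 3,4-dimethoxyphenyl at the same place gives a 1.0-fold higher number from compound 1 to compound 3 (0.01 log units; within the scatter) and shows that the ring with three fluorines and the ring with two methoxy groups cannot be told apart here either, so all three rings shown at this position give numbers within the scatter of one another. Nothing measured here offers an explanation for this flat picture.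

Going by these compounds, it remains open whether a phenyl ring carrying an amine or a carboxylic acid at this place, or a longer chain in place of the ethenyl link, would give a number beyond the scatter. All three compounds also keep the trimethoxybenzoyl group, so what a bare benzoyl group would do to the number is open as well.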